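The source may hold more compounds than are shown below. What is called first, only, known or untested is meant among the compounds shown, and "the series" means these compounds.

Measured so far:
compound 1 `O[C@H](c1ccccn1)[C@]1(c2cccc(OC(F)(F)F)c2)C[C@@H](O)C1` with 80 nM
compound 2 `O[C@H](c1ccccn1)[C@]1(c2cccc(C(F)(F)F)c2)C[C@H](O)C1` with 90 nM
compound 3 `C[C@]1(O)C[C@@](c2cccc(C(F)(F)F)c2)([C@H](O)c2ccccn2)C1` with 300 nM

All three were tested in an assay on HEK293 cells for antagonist activity at transient receptor potential cation channel subfamily V member 3 (Homo sapiens), read by FLIPR and calcium flux; a higher number here means a weaker inhibitor, a lower number a stronger inhibitor. Compound 3 stands highest of the three numbers, and its gap to compound 2 and to compound 1 lies beyond the usual scatter, so compound 3 is the weakest inhibitor of the set.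

Compound 4 `O[C@H](c1ccccn1)[C@]1(c2cccc(C(F)(F)F)c2)C[C@@H](O)C1` differs from compound 3 in one place: hydrogen in place of methyl on a saturated ring carbon. Among the measured compounds shown here, no measured pair in this set shows the effect of exactly that change, so the expected size of the step rests only on the spread of the numbers already seen. Since compounds 1 and 2, which give the lower values, set the range of what the shared core has reached, the step from compound 3 to compound 4 is expected to go downward, a 2.7-fold lower number from compound 3 to compound 4 (0.44 log units; beyond the scatter), toward stronger inhibition. Compound 4 is expected to give about 110 nM, within roughly 40 nM to 300 nM.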

Compound 4, antagonist equilibrium constant: 210 nM
Compound 4: the middle estimate sits 1.9-fold (0.28 log units) below what was measured, and the stated range covers the measured number.
By their numbers in this assay, from the lowest: compounds 1 and 2 (each within the scatter of the next); then compounds 4 and 3 (each within the scatter of the next).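

In this assay, hydrogen in place of methyl on the saturated ring carbon gives a 1.4-fold lower number from compound 3 to compound 4 (0.15 log units; within the scatter), so this change makes no clear difference. Trifluoromethyl in place of trifluoromethoxy on an aromatic carbon gives a 2.6-fold higher number from compound 1 to compound 4 (0.42 log units; beyond the scatter). Configuration alone also shifts the number, with a 2.3-fold higher number from compound 2 to compound 4 (0.37 log units; beyond the scatter), and this step can be traced to one thing: the fact that compounds 2 and 4 differ only in the configuration as drawn.

Going by these compounds, it remains open whether an amine or an ethyl group on that ring carbon would change the number more than methyl does. Also open, on these data alone, is how the trifluoromethoxy compounds respond to the same change in configuration.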